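The source may report more compounds than this note shows. Statements on the series, on what has been measured and on what is new or still open speak of the compounds shown alone.

Measured in a physicochemical assay for solubility, using the shake flask method, measured as kinetic solubility, at pH 7.4; on this read-out higher numbers stand for higher solubility and lower numbers for lower solubility:
compound 1 `COc1ccccc1Nc1nc(-c2ccccn2)cs1` gives 1200 nM;
compound 2 `COC(=O)c1cccc(-c2cnc(Nc3cccc(F)c3)o2)c1` gives < 1000 nM, a limit of the assay;
compound 3 `COC(=O)c1cccc(-c2cnc(Nc3ccc(F)cc3)o2)c1` gives < 1000 nM, a limit of the assay.

Compound 3 thus stands at the lower limit of this assay, with no number of its own. Among the measured compounds shown here, the one measured step, a step that the two limits leave unreadable from compound 2 to compound 3, is unreadable, since both of its values are limits (the limit of < 1000 nM in this assay, at which 2 of the 3 values shown sit). Compound 4 `CC(=O)Nc1cccc(-c2cnc(Nc3ccc(F)cc3)o2)c1` differs from compound 3 by acetamido in place of methoxycarbonyl on an aromatic carbon. For the measured compounds named here, no measured step bears on this change, so the expectation rests only on where compound 3 sits. Compound 4 is expected to give about 1500 nM, within 300 nM to 8000 nM, which would mean an estimated step of an at least 1.5-fold higher number from compound 3 to compound 4 (0.17 log units; that floor lies within the scatter), though a value reported only as a limit remains quite possible.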

Compound 4, solubility: 5000 nM
Estimate against measurement, compound 4: 3.3-fold (0.52 log units) below; the range from low to high includes it.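

Placing acetamido instead of methoxycarbonyl on this aromatic carbon, meta to a large group, gives the series its first readable step in this assay: an at least 5.0-fold higher number from compound 3 to compound 4 (0.69 log units; beyond the scatter). Compound 4 thus has a number of its own, showing that this position can carry the read-out clear of the limit. The step gives only a floor, not a full size, because compound 3 has only a limit: the limit of < 1000 nM in this assay, at which 2 of the 4 values shown sit.

From the compounds shown here alone, its true size remains open, as does whether the same change would hold with the 3-fluorophenyl group of compound 2. Going by these compounds, how an amine, a carboxylic acid or a longer chain would read at this position also remains open.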